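A few compounds are considered here, and "the series" means these few. Any claim that something is new, unique, unknown or untested is made for them only; others in the source may bear on it.

Compound 1 `O=C(Cn1nc(Cc2ccccc2)c2ccccc2c1=O)Nc1ccccc1`: 95400 nM
Compound 2 `O=C(Cn1nc(Cc2ccccc2)c2ccccc2c1=O)Nc1cccc(Cl)c1`: 3680 nM

In a functional assay on HT-29 cells (Homo sapiens) for antiproliferative activity, read by sulforhodamine B assay, with a stated time of 72 h (on this read-out higher numbers stand for weaker inhibition and lower numbers for stronger inhibition), compound 2 gives the lower of the two numbers, 3680 nM, which makes it the stronger inhibitor of this pair. Within the data shown here, only one measured step exists so far: a 26-fold lower number from compound 1 to compound 2 (1.41 log units; beyond the scatter). It came with chloro in place of hydrogen on an aromatic carbon.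

The next compound, compound 3 `O=C(Cn1nc(Cc2ccccc2)c2ccccc2c1=O)Nc1ccc(Cl)cc1`, has the same atoms as compound 2, joined differently: 4-chlorophenyl in place of 3-chlorophenyl on an amide-type nitrogen. In words, 4-chlorophenyl stands in place of 3-chlorophenyl on an amide-type nitrogen. Among the measured compounds shown here, the one measured step bears on this only indirectly. For the measured compounds named here, it shows that adding a chloro can change the number greatly, but it compares no two chloro compounds. With chloro kept, the working expectation is no step beyond the scatter, with no firm direction and only a slight lean towards a higher number. The expected change is a 1.2-fold higher number from compound 2 to compound 3 (0.09 log units; within the scatter). The range stays wide, since the large size of a 26-fold lower number from compound 1 to compound 2 (1.41 log units; beyond the scatter) leaves open that the gain depends on where chloro sits. For compound 3 the estimate is 4500 nM, with an expected range of 1200 nM to 18000 nM.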

Compound 3, half-maximal inhibitory concentration: 2980 nM
Beside the measured number, compound 3's estimate is 1.5-fold (0.18 log units) above it; low and high end bracket the measured number.
By their numbers in this assay, from the lowest: compounds 3 and 2 (each within the scatter of the next); then compound 1.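

In this assay, moving the chloro gives a 1.2-fold lower number from compound 2 to compound 3 (0.09 log units; within the scatter) and so stays within the scatter, which means that 4-chlorophenyl and 3-chlorophenyl on the amide-type nitrogen cannot be told apart on this read-out. The large gain over the compound without chloro also holds for the second placement, with a 32-fold lower number from compound 1 to compound 3 (1.51 log units; beyond the scatter) as the step, so it is not tied to just one of the two chlorophenyl groups shown. No measured evidence here bears on what lies behind these numbers.

On these data alone, what remains open is whether the gain belongs to chloro itself or would also come with another group on that aromatic ring, such as fluoro, methoxy or a carboxylic acid. Also open, as far as these compounds go, is how much the numbers depend on the shared core, which is the same in all three compounds, so these comparisons speak only about the group on the amide-type nitrogen.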